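A Fluorine on the Aniline Ring of Compound 3

The source may hold more compounds than are shown below. What is called first, only, known or untested is meant among the compounds shown, and "the series" means these compounds.

Of the compounds shown here, three sharing one core have been measured in a functional assay on MCF7 cells (Homo sapiens) for cytotoxicity, read by MTT assay, with a stated time of 72 h; a higher number here means a weaker inhibitor, a lower number a stronger inhibitor. Compound 1 `Cc1cc(=O)n(-c2ccc(Br)cc2F)nc1C(=O)Nc1ccc(Oc2ncnc3c2ccn3C)cc1` gives 27700 nM. Compound 2 `Cc1cc(=O)n(-c2ccccc2C(F)(F)F)nc1C(=O)Nc1ccc(Oc2ncnc3c2ccn3C)cc1` gives 7840 nM, and compound 3 `Cc1cc(=O)n(-c2ccccc2Cl)nc1C(=O)Nc1ccc(Oc2ncnc3c2ccn3C)cc1` gives 4130 nM. Compound 3 therefore holds the lowest number of the three: the steps of a 6.7-fold lower number from compound 1 to compound 3 (0.83 log units; beyond the scatter) and a 3.5-fold lower number from compound 1 to compound 2 (0.55 log units; beyond the scatter) both lie beyond the scatter, whereas the step of a 1.9-fold lower number from compound 2 to compound 3 (0.28 log units; within the scatter) does not, so compound 3 and compound 2 cannot be set in order against each other.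

Compound 4 `Cc1cc(=O)n(-c2ccccc2Cl)nc1C(=O)Nc1ccc(Oc2ncnc3c2ccn3C)c(F)c1` keeps the 2-chlorophenyl group of compound 3 and differs from it in one place only: fluoro in place of hydrogen on an aromatic carbon. None of the three measured steps touches this ring; all of them change the aryl group on the aromatic nitrogen, and the two steps beyond the scatter replace 4-bromo-2-fluorophenyl with a different aryl. Within the data shown here, the numbers therefore say nothing about a fluoro at this position, and no step in this assay can be predicted with any confidence. Compound 4 is expected to stay close to compound 3, giving an estimated 4000 nM with a range from 1500 nM to 11000 nM. The step of a 1.0-fold lower number from compound 3 to compound 4 (0.01 log units; within the scatter) is thus expected to lie within the scatter.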

Compound 4, half-maximal inhibitory concentration: > 60000 nM
Compound 4 gave a limit, no number; the forecaster's own chance of this, stated with the estimate: 5%; middle value at least 15-fold (1.17 log units) from the limit.
By their numbers in this assay, from the lowest: compounds 3 and 2 (each within the scatter of the next); then compound 1. At a limit, above all of these: compound 4.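

In this assay, among these compounds, the step of an at least 14-fold higher number from compound 3 to compound 4 (1.16 log units; beyond the scatter) is large, and it shows what the earlier compounds could not: this position is sensitive to change, even though the earlier steps moved only the aryl group on the aromatic nitrogen. Compound 4 keeps the 2-chlorophenyl group of compound 3, so this step belongs to one change alone: a fluoro enters where compound 3 carries a hydrogen, on an aromatic carbon that is ortho to a large group and meta to a large group. The value of compound 4 is a limit and not a number, and it is the only such value among these compounds: the limit of > 60000 nM in this assay, at which 1 of the 4 values shown sits.

The compounds shown leave open whether the step is particular to fluoro or whether any group at this position, such as a methyl, a methoxy or an amine, would give a similar result. They also leave open whether the same fluoro would have a similar effect alongside the 2-(trifluoromethyl)phenyl group or the 4-bromo-2-fluorophenyl group, and what lies behind the step.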